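Swapping a Ring Amine for Dimethylamino: Cytotoxicity Outlook

A few compounds are considered here, and "the series" means these few. Any claim that something is new, unique, unknown or untested is made for them only; others in the source may bear on it.

Compound 1 `CN(C)c1cc2[nH]c(C3CCCCC3)nc2cc1NC(=O)c1ccc(Br)cc1` and compound 2 `O=C(Nc1cc2nc(C3CCCCC3)[nH]c2cc1N1CCCC1)c1ccccc1` share the same core and differ in two places. In an ADME assay on Vero cells (Chlorocebus sabaeus) for cytotoxicity, read by resazurin assay, with a stated time of 3 days (on this read-out higher numbers stand for weaker inhibition and lower numbers for stronger inhibition), compound 1 gives > 100 ug/mL, which is a limit of the assay rather than a measured number. Compound 2 gives > 100 ug/mL in this assay, again a limit. Both readings therefore sit at the limit of > 100 ug/mL in this assay, at which 2 of the 2 values shown sit. Compound 3 `CN(C)c1cc2[nH]c(C3CCCCC3)nc2cc1NC(=O)c1ccccc1` carries dimethylamino in place of pyrrolidin-1-yl on an aromatic carbon. For the measured compounds named here, no measured step for such a change is available here. The expected step that the limit leaves unreadable from compound 2 to compound 3 is none beyond the scatter. Compound 3 is therefore estimated at 150 ug/mL, with a range from 60 ug/mL to 400 ug/mL, most likely reported again only as a limit.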

Compound 3, half-maximal inhibitory concentration: > 100 ug/mL
Compound 3: no number, only a limit; the forecaster's own chance of this, stated with the estimate: 80%; the middle value is on the limit's open side.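

For the compounds shown here, no step from compound 1 or compound 2 to compound 3 can be read, since all three readings are limits: the limit of > 100 ug/mL in this assay, at which 3 of the 3 values shown sit.

In this assay the compounds shown leave open how far swapping pyrrolidin-1-yl for dimethylamino, or bromo for hydrogen, shifts cytotoxicity.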